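This account rests on a few compounds, and the source may have more. Where it says the series, first, only, none or still open, it means among the compounds named here.

In a functional assay on CCRF-CEM cells (Homo sapiens) for antiproliferative activity, read by cell counting, with a stated time of 2 days (a lower number here means a stronger inhibitor, a higher number a weaker inhibitor), compound 1 `COc1cc(C(=O)c2sc(N)nc2N)cc(OC)c1OC` gives 42000 nM. Compound 2 `CCN(CC)c1nc(N)c(C(=O)c2cc(OC)c(OC)c(OC)c2)s1` gives 78000 nM. Compound 3 `COc1cc(C(=O)c2sc(N3CCCC3)nc2N)cc(OC)c1OC` gives 320 nM, the lowest of the three numbers.

The next compound, compound 4 `COc1ccc(C(=O)c2sc(N3CCCC3)nc2N)cc1OC`, differs from compound 3 by hydrogen in place of methoxy on an aromatic carbon of a six-membered aromatic ring of carbon only.

Among the compounds with values here, no measured step touches this place. All three exchange a different group, the amino, diethylamino or pyrrolidin-1-yl group. Two are large, a 130-fold lower number from compound 1 to compound 3 (2.12 log units; beyond the scatter) and a 240-fold lower number from compound 2 to compound 3 (2.39 log units; beyond the scatter), while a 1.9-fold higher number from compound 1 to compound 2 (0.27 log units; within the scatter) stays within the scatter. They show that a single change in this small set can move the number far, but they do not reveal the direction of this new change.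

Since compound 3 at 320 nM already has the lowest number, a moderate step upward beyond the scatter is expected in this assay, with wide uncertainty. The expected change is a 7.8-fold higher number from compound 3 to compound 4 (0.89 log units; beyond the scatter). The estimate for compound 4 is 2500 nM, with an expected range from 500 nM to 15000 nM.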

Compound 4, half-maximal inhibitory concentration: 19000 nM
Compound 4: the middle estimate sits 7.6-fold (0.88 log units) below what was measured; measured number outside the range, above it.
By their numbers in this assay, from the lowest: compound 3; then compound 4; then compounds 1 and 2 (each within the scatter of the next).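

In this assay, the methoxy group that leaves here matters a great deal: its loss gives a 59-fold higher number from compound 3 to compound 4 (1.77 log units; beyond the scatter), a large step from one small change. The earlier steps shown here all changed the amino, diethylamino or pyrrolidin-1-yl group, whereas this one shows that the number also responds strongly to the six-membered aromatic ring of carbon only, even with the pyrrolidin-1-yl group kept in place. No measurement here explains why this methoxy group counts for so much.

As far as these compounds go, it remains open whether a hydroxyl group, an ethoxy group or a chlorine atom at this place would keep the number close to that of compound 3. From the compounds shown here alone, it is also open whether losing this methoxy group would cost as much with amino or diethylamino in place of pyrrolidin-1-yl.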